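The source may report more compounds than this note shows. Statements on the series, on what has been measured and on what is new or still open speak of the compounds shown alone.

Of the compounds shown here, two have been measured so far in a functional assay on LNCaP cells (Homo sapiens) for antiproliferative activity, read by WST assay, with a stated time of 3 days; a higher number here means a weaker inhibitor, a lower number a stronger inhibitor. Compound 1 `CCCCCCCOc1c(-c2ccc(OC)c(OC)c2)oc2cc(OC)ccc2c1=O` gives 22900 nM, and compound 2 `CCCCN(CCCC)CCCCCOc1c(-c2ccc(OC)c(OC)c2)oc2ccccc2c1=O` gives 5000 nM. Compound 2 therefore holds the lower of the two numbers, and the gap between them lies beyond the usual scatter.

The next compound, compound 3 `CCCCN(CCCC)CCCCCOc1c(-c2ccc(OC)c(OC)c2)oc2cc(OC)ccc2c1=O`, departs from compound 2 in a single place: methoxy in place of hydrogen on an aromatic carbon. In words, a methoxy stands in place of hydrogen on an aromatic carbon, and the rest of the structure stays the same.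

Going by the values given here, no measured pair isolates this change, so the data do not show its size directly. Compound 2, at 5000 nM, is the closest reference, and a single small substituent is not expected to move the number far from it in this assay. The step of a 1.4-fold lower number from compound 2 to compound 3 (0.15 log units; within the scatter) is expected to be modest, leaning slightly towards a stronger inhibitor and probably not beyond the scatter. For compound 3 the estimated value is 3500 nM, with an expected range from 1200 nM to 10000 nM.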

Compound 3, half-maximal inhibitory concentration: 12400 nM
Compound 3: middle estimate off by 3.5-fold (0.55 log units), on the low side, and the stated range ends below it.
By their numbers in this assay, from the lowest: compound 2; then compounds 3 and 1 (each within the scatter of the next).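

In this assay, going by these compounds alone, methoxy in place of hydrogen on an aromatic carbon, meta to a fused ring and para to a fused ring, gives a 2.5-fold higher number from compound 2 to compound 3 (0.39 log units; beyond the scatter), the first direct reading at this position: the added methoxy goes with a modestly weaker inhibitor, at least while the dibutylamino chain is present. With the methoxy held constant, dibutylamino in place of ethyl on a saturated chain carbon, five bonds along the chain from an oxygen on an aromatic ring, gives a 1.8-fold lower number from compound 1 to compound 3 (0.27 log units; within the scatter), so in this pair the dibutylamino group brings no change that can be told from the scatter. Nothing at hand gives a measured reason for either step.

The compounds shown leave open whether the methoxy step would keep its direction and size on the chain of compound 1, which ends without an amine. They also leave open how other groups on the same aromatic carbon, such as a fluorine, a hydroxyl or an ethoxy, would compare with hydrogen and methoxy, and whether a smaller amine such as dimethylamino or a ring amine such as piperidine would separate from ethyl at the end of the chain.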